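Removing one methoxy group from compound 2

The source may report more compounds than this note shows. Statements on the series, on what has been measured and on what is new or still open speak of the compounds shown alone.

In a functional assay on U-251 cells (Homo sapiens) for inhibition, read by sulforhodamine B assay, with a stated time of 48 h (a higher number here means a weaker inhibitor of growth, a lower number a stronger inhibitor of growth), compound 2 `COc1ccc(CNc2nc3cc(N)cc(N)c3nc2-c2ccccc2)cc1OC` gives 38900 nM, the highest of the two numbers recorded; the nearest is compound 3 `COc1cc(CNc2nc3cc(N)cc(N)c3nc2-c2ccccc2)cc(OC)c1OC`, which gives 6310 nM. Compound 1 `CCOC(=O)[C@H](CCC(=O)O)NC(=O)c1ccc(CNc2nc3cc(N)cc(N)c3nc2-c2ccccc2)cc1` gives only a limit, < 100000 nM, and not a number. The step from compound 2 to compound 3 adds a methoxy group on an aromatic carbon and reads a 6.2-fold lower number from compound 2 to compound 3 (0.79 log units; beyond the scatter).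

Compound 4 `COc1ccc(CNc2nc3cc(N)cc(N)c3nc2-c2ccccc2)cc1` is not yet measured. It differs from compound 2 by hydrogen in place of methoxy on an aromatic carbon; cut one bond further out, the change reads 3,4-dimethoxyphenyl to 4-methoxyphenyl. Among the measured compounds shown here, the one measured step that bears on it runs in the opposite direction: adding a methoxy in compound 3 gave a 6.2-fold lower number from compound 2 to compound 3 (0.79 log units; beyond the scatter). Taking a methoxy away from compound 2 is therefore expected to move this assay toward a higher number, a modest step, though whether the two methoxy groups act alike is not shown by these three compounds. The expected step is a 1.5-fold higher number from compound 2 to compound 4 (0.19 log units; within the scatter). Compound 4 is thus estimated at 60000 nM, within 20000 nM to 130000 nM, and it may well reach the assay limit.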

Compound 4, concentration for total growth inhibition: 26300 nM
Estimate against measurement, compound 4: 2.3-fold (0.36 log units) above; the range from low to high includes it.
By their numbers in this assay, from the lowest: compound 3; then compounds 4 and 2 (each within the scatter of the next).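

In this assay the change from 3,4-dimethoxyphenyl to 4-methoxyphenyl reads a 1.5-fold lower number from compound 2 to compound 4 (0.17 log units; within the scatter) and so shows no difference that can be told from the scatter between hydrogen and methoxy at this place, ortho to a methoxy group and meta to a large group. The other step from the same compound, a 6.2-fold lower number from compound 2 to compound 3 (0.79 log units; beyond the scatter), lies beyond the scatter, so the two methoxy changes on this ring do not read alike. Compound 1 alone stands as a limit, and compound 4 does not join it: the limit of < 100000 nM in this assay, at which 1 of the 4 values shown sits.

As far as these compounds go, whether a hydroxyl group, a fluorine atom or an amine at this place would read differently stays open. So does the part played by the remaining methoxy group, and whether a longer chain such as ethoxy would behave as methoxy does.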